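Trifluoromethoxy in place of fluoro: next step in the series

A few compounds are considered here, and "the series" means these few. Any claim that something is new, unique, unknown or untested is made for them only; others in the source may bear on it.

Compound 1 `COc1ccc(C(N)=O)cc1/C=C/c1ccc(C#N)cc1` gives 16000 nM
Compound 2 `COc1ccc(C(N)=O)cc1/C=C/c1cccc(C#N)c1` gives 19000 nM
Compound 3 `COc1ccc(C(N)=O)cc1/C=C/c1ccccc1F` gives 26000 nM

All three values come from an ADME assay on HCT-116 cells (Homo sapiens) for antiproliferative activity (on this read-out higher numbers stand for weaker inhibition and lower numbers for stronger inhibition), and lie within the scatter of each other. Compound 3 at 26000 nM therefore stands level with compound 1 and compound 2, and no order can be read among them.

Compound 4 `COc1ccc(C(N)=O)cc1/C=C/c1ccccc1OC(F)(F)F` has not yet been measured. It carries trifluoromethoxy in place of fluoro on an aromatic carbon ortho to a large group. Among the measured compounds shown here, no measured pair differs in one place only, so nothing shows directly what such an exchange does to the number. For the measured compounds named here, the only guide is that compound 1 at 16000 nM with its nitrile and compound 3 at 26000 nM with its fluoro stay within the scatter of each other. In this assay no shift beyond the scatter is therefore expected, in either direction. The estimated change is a 1.3-fold lower number from compound 3 to compound 4 (0.11 log units; within the scatter) and would remain within that scatter. For compound 4 the estimate is 20000 nM with an expected range from 9000 nM to 45000 nM around it.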

Compound 4, half-maximal inhibitory concentration: 36000 nM
Estimate against measurement, compound 4: 1.8-fold (0.26 log units) below; low and high end bracket the measured number.
By their numbers in this assay, from the lowest: compounds 1, 2, 3 and 4 (each within the scatter of the next, the first and the last beyond it).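

Compound 3 and compound 4 form the only pair shown that differs in one place, so the exchange can now be read directly. In this assay, trifluoromethoxy in place of fluoro on an aromatic carbon ortho to a large group gives a 1.4-fold higher number from compound 3 to compound 4 (0.14 log units; within the scatter), so at this position the two groups cannot be told apart, even though the entering group is the larger and brings a hydrogen-bond acceptor. No accompanying measurement bears on this result, and the data offer no explanation for it.

Going by these compounds, whether an amine, a carboxylic acid or a longer alkyl chain on this same carbon would move the number beyond the scatter remains open. Also open, on these data alone, is whether the same exchange reads alike on another aromatic carbon or on a differently substituted core.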